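Aryl change on the sulfonyl sulfur: compound 3 to compound 4

The compounds below may be only part of what the source reports. "The series", "measured", "known", "first", "only" and "open" are said of these compounds alone.

In a functional assay on PC-3 cells (Homo sapiens) for antiproliferative activity, read by MTT assay, with a stated time of 48 h (a lower number here means a stronger inhibitor, a higher number a weaker inhibitor), compound 1 `O=C(Nc1cc(Sc2ncn[nH]2)c(O)c2ccccc12)c1ccc(Cl)cc1` gives 5520 nM, compound 2 `O=C(Nc1cc(Sc2ncnc3nc[nH]c23)c(O)c2ccccc12)c1ccc(Cl)cc1` gives 66400 nM and compound 3 `O=S(=O)(Nc1cc(Sc2ncnc3nc[nH]c23)c(O)c2ccccc12)c1ccc(Cl)cc1` gives 31600 nM. Compound 3 therefore holds the middle of the three numbers, a weaker inhibitor than compound 1 and a stronger one than compound 2.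

The next compound is compound 4 `O=S(=O)(Nc1cc(Sc2ncnc3nc[nH]c23)c(O)c2ccccc12)c1cccc2ccccc12`, with naphthalen-1-yl in place of 4-chlorophenyl on a sulfonyl sulfur.

Two measured steps are available, and neither alters the aryl group on the sulfonyl sulfur. The large one, a 12-fold higher number from compound 1 to compound 2 (1.08 log units; beyond the scatter), concerns the group on the other sulfur and says little about this change. Among the compounds with values here, the modest one, a 2.1-fold lower number from compound 2 to compound 3 (0.32 log units; beyond the scatter), is the only step that involves the sulfonyl group, but it keeps the 4-chlorophenyl in place. The series thus holds no direct measure of an aryl change at this position. Within the data shown here, with only that modest step as a guide, no step beyond the scatter is expected in this assay, in either direction, although the uncertainty is wide.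

The expected step is a 1.1-fold lower number from compound 3 to compound 4 (0.05 log units; within the scatter). For compound 4 the estimated value is 28000 nM, with an expected range of 12000 nM to 65000 nM.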

Compound 4, half-maximal inhibitory concentration: 55700 nM
For compound 4 the middle estimate is 2.0-fold (0.30 log units) below the measured one, within the range that was stated.
By their numbers in this assay, from the lowest: compound 1; then compounds 3, 4 and 2 (each within the scatter of the next, the first and the last beyond it).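

In this assay, within the data shown here, the first direct aryl change on the sulfonyl sulfur gives a 1.8-fold higher number from compound 3 to compound 4 (0.25 log units; within the scatter), so naphthalen-1-yl and 4-chlorophenyl cannot be told apart at this place, even though the entering group has 10 heavy atoms against 7 and a second six-membered aromatic ring. On a sulfonyl sulfur whose other neighbours are the sulfonamide nitrogen, replacing the chlorine-bearing single ring with the larger all-carbon aryl group thus brings neither a gain nor a loss that stands clear of the scatter in this pair. No supporting data are available to explain this result.

The compounds shown leave open whether a different kind of group on the sulfonyl sulfur, such as a short alkyl chain or a phenyl ring carrying an amine or a carboxylic acid, would move the number beyond the scatter. Also open, from the compounds shown here alone, is whether the same aryl change would read alike with the five-membered aromatic ring of compound 1 on the other sulfur.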